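A few compounds are considered here, and "the series" means these few. Any claim that something is new, unique, unknown or untested is made for them only; others in the source may bear on it.

Three compounds have been measured in a functional assay on MCF7 cells (Homo sapiens) for antiproliferative activity, read by MTT assay, with a stated time of 72 h; on this read-out higher numbers stand for weaker inhibition and lower numbers for stronger inhibition:
Compound 1, `CC(C)N1C(=O)COc2ccc(-c3cccc(NS(=O)(=O)c4ccc(F)cc4)c3)cc21`, gives 26000 nM.
Compound 2, `O=C1COc2ccc(-c3cccc(NS(=O)(=O)c4ccc(F)cc4)c3)cc2N1c1ccc(Cl)cc1`, gives 39800 nM.
Compound 3, `COc1ncc(-c2ccc3c(c2)N(c2ccc(Cl)cc2)C(=O)CO3)cc1NS(=O)(=O)c1ccc(F)cc1`, gives 27600 nM.

All three values lie within the scatter of one another, so none of them can be called stronger or weaker than the rest. Compound 4, `COc1ncc(-c2ccc3c(c2)N(C(C)C)C(=O)CO3)cc1NS(=O)(=O)c1ccc(F)cc1`, has not yet been measured. It differs from compound 3 in one place: isopropyl in place of 4-chlorophenyl on an amide-type nitrogen in a ring. The same change has been made once before among the measured compounds, from compound 2 to compound 1: isopropyl in place of 4-chlorophenyl on an amide-type nitrogen in a ring, where it gave a 1.5-fold lower number from compound 2 to compound 1 (0.18 log units; within the scatter). The cores of compound 3 and compound 2 are not the same, and the difference between them is not broken down here; the place of the change, however, is described in identical words for both pairs, so it counts as the same change. Because the earlier step of a 1.5-fold lower number from compound 2 to compound 1 (0.18 log units; within the scatter) stayed within the scatter, the step from compound 3 to compound 4 is expected to be of similar size, a 1.3-fold lower number from compound 3 to compound 4 (0.10 log units; within the scatter), in this assay. Compound 4 is therefore estimated at 22000 nM, with a likely range from 11000 nM to 44000 nM.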

Compound 4, half-maximal inhibitory concentration: 17000 nM
Compound 4: the middle estimate sits 1.3-fold (0.11 log units) above what was measured, within the range that was stated.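

In this assay, placing isopropyl instead of 4-chlorophenyl on the amide-type nitrogen gives a 1.6-fold lower number from compound 3 to compound 4 (0.21 log units; within the scatter), and this step agrees with the one seen earlier on the other core: the same change on two cores in this assay, a 1.5-fold lower number (0.18 log units; within the scatter) from compound 2 to compound 1 and a 1.6-fold lower number (0.21 log units; within the scatter) from compound 3 to compound 4, 1.1-fold (0.03 log units) apart, within the scatter of two such steps. On these two cores, then, the change behaves alike, and the result on one core would have been a fair guide to the result on the other. It does not show that the swap truly alters antiproliferative activity, since each step on its own lies within the scatter; what carries over is the lack of a clear difference, and two pairs in a single assay cannot establish a rule for the whole series.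

The compounds shown leave open whether any group on this nitrogen could move the number beyond the scatter, for example a longer chain ending in an amine or a carboxylic acid. They also leave open whether such a group would behave alike on both cores.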